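Pyrazolylpyridine amides: fluoro substitution on the benzamide ring

The source may report more compounds than this note shows. Statements on the series, on what has been measured and on what is new or still open speak of the compounds shown alone.

Measured so far:
compound 1 `COc1cccc(-c2nn(-c3ccccc3)cc2-c2ccnc(NCCNC(=O)Nc3cccc(C(F)(F)F)c3)c2)c1` — 2130 nM
compound 2 `O=C(NCCCNc1cc(-c2cn(-c3ccccc3)nc2-c2cccc(O)c2)ccn1)c1ccccc1` — 750 nM

In a functional assay on K562 cells (Homo sapiens) for antiproliferative activity (on this read-out lower numbers stand for stronger inhibition of growth and higher numbers for weaker inhibition of growth), compound 2 gives 750 nM. Compound 1 gives 2130 nM in this assay, a higher number, and that gap lies beyond the scatter. Compound 2 thus stands as the lower of the two numbers at hand.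

Compound 3 `O=C(NCCCNc1cc(-c2cn(-c3ccccc3)nc2-c2cccc(O)c2)ccn1)c1ccc(F)cc1` is not yet measured. It differs from compound 2 by fluoro in place of hydrogen on an aromatic carbon, with the benzamido group becoming ((4-fluorophenyl)carbonyl)amino. Among the measured compounds shown here, no measured pair with a change of this kind exists within these two compounds, so no step size can be drawn from them. The expectation is a change of no more than the usual scatter in either direction. Compound 3 is therefore estimated at 650 nM in this assay, with a range from 300 nM to 1500 nM, meaning an expected step of a 1.2-fold lower number from compound 2 to compound 3 (0.06 log units; within the scatter).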

Compound 3, concentration for 50% growth inhibition: 1930 nM
Compound 3: middle estimate off by 3.0-fold (0.47 log units), on the low side; the measured number lies above the stated range.
By their numbers in this assay, from the lowest: compound 2; then compounds 3 and 1 (each within the scatter of the next).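

In this assay, the para position of the benzamido phenyl ring responds to even the smallest substitution: fluoro in place of hydrogen gives a 2.6-fold higher number from compound 2 to compound 3 (0.41 log units; beyond the scatter) and thus weaker inhibition of growth. Among the compounds shown here, this is the first single-place step, and it shows that one added fluorine atom, with no hydrogen-bond donor or acceptor counted for the group, can move the number beyond the scatter. No measurement at hand bears on the reason for this shift.

From the compounds shown here alone, it remains open whether the shift is specific to fluoro or would also appear with chloro, methoxy or an amine at this aromatic carbon. Also open, going by these compounds, is how fluoro behaves at other carbons of this ring, and whether a shorter or longer chain to the amide changes the size of the step.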